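The source may report more compounds than this note shows. Statements on the series, on what has been measured and on what is new or still open speak of the compounds shown alone.

Measured so far:
compound 1 `O=c1c(Cl)c(CSC(=S)N2CCCCC2)oc2ccccc12` — 3300 nM
compound 2 `CC(C)N(C(=S)SCc1oc2ccccc2c(=O)c1Cl)C(C)C` — > 40000 nM
compound 3 `COc1ccc2oc(CSC(=S)N(C(C)C)C(C)C)cc(=O)c2c1` — 19100 nM

Working notes. In a functional assay on LM7 cells (Homo sapiens) for antiproliferative activity, read by MTT assay, with a stated time of 72 h (a higher number here means a weaker inhibitor, a lower number a stronger inhibitor), compound 1 gives 3300 nM. In this assay compound 2 gives > 40000 nM; this is a limit of the assay and not a number, as marked by the limit of > 40000 nM in this assay, at which 1 of the 3 values shown sits. In this assay compound 3 gives 19100 nM, the highest of the two numbers recorded, with compound 1 as its nearest neighbour.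

Compound 2 and compound 1 share a core and differ in one place: piperidin-1-yl in place of diisopropylamino on a thiocarbonyl carbon. That change produced an at least 12-fold lower number from compound 2 to compound 1 (1.08 log units; beyond the scatter). The core of compound 3 differs from the core of compound 2, but the difference between the two cores is not broken down here.

Compound 4 `COc1ccc2oc(CSC(=S)N3CCCCC3)cc(=O)c2c1` has not yet been measured in this assay. It stands to compound 3 as compound 1 stands to compound 2: piperidin-1-yl in place of diisopropylamino on a thiocarbonyl carbon. The place lines of the two changes agree word for word, so this is the same change on a different core.

For compound 4 the step of a 12-fold lower number from compound 3 to compound 4 (1.08 log units; beyond the scatter) is expected in this assay, resting on the step of an at least 12-fold lower number from compound 2 to compound 1 (1.08 log units; beyond the scatter) seen on the other core, with the caveat that the earlier step starts from a limit and its full size is therefore not fixed. On that basis compound 4 is estimated at 1600 nM, with a range from 400 nM to 6000 nM.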

Compound 4, half-maximal inhibitory concentration: 5000 nM
Compound 4: middle estimate off by 3.1-fold (0.49 log units), on the low side, within the range that was stated.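

In this assay, piperidin-1-yl in place of diisopropylamino on a thiocarbonyl carbon again gives a lower number on the second core, with a 3.8-fold lower number from compound 3 to compound 4 (0.58 log units; beyond the scatter), so the direction of the change carries over in the two pairs shown, but its size does not carry over unchanged: the same change on two cores in this assay, an at least 12-fold lower number (1.08 log units; beyond the scatter) from compound 2 to compound 1 and a 3.8-fold lower number (0.58 log units; beyond the scatter) from compound 3 to compound 4, at least 3.1-fold (0.50 log units) apart, beyond the scatter of two such steps. The earlier step starts from compound 2, whose reading is a limit of the assay and not a number: the limit of > 40000 nM in this assay, at which 1 of the 4 values shown sits. The two pairs therefore show a shared direction and a smaller step on the core of compound 3, but they do not fix the full size of the earlier step, and two cores say nothing about how the change behaves on any further core.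

Still open, from the compounds shown here alone, is how other amines on the thiocarbonyl carbon, such as morpholine, pyrrolidine or diethylamino, would read in this assay, and whether they would also give lower numbers than diisopropylamino on both cores. Also open, going by these compounds, is which part of the difference between the two cores goes with the different size of the step, as these four compounds do not break that difference down.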